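The source may hold more compounds than are shown below. What is called first, only, known or untested is meant among the compounds shown, and "the series" means these compounds.

Compound 1 `COc1cccc2cc(C(=O)O)cnc12` carries a methoxy on its core and was tested in a functional assay on the whole organism (strain Sprague-Dawley) for inhibition, with Rattus norvegicus as the target (on this read-out higher numbers stand for an effect only at larger amounts of compound and lower numbers for an effect already at smaller amounts), where compound 1 gives 25 mg/kg. Of the two numbers on record in this assay, this is the higher one; the nearest neighbour, compound 2 `CCCCc1ccc2ncc(-c3nn[nH]n3)cc2c1`, gives 5 mg/kg in this assay, and the gap between the two lies beyond the usual scatter of the measurement. Compound 3 `COc1ccc2cc(C(=O)O)cnc2c1` gives only > 25 mg/kg in this assay, which is a limit of the assay rather than a number, as noted by the limit of > 25 mg/kg in this assay, at which 1 of the 3 values shown sits. Compound 4 `Cc1cccc2cc(C(=O)O)cnc12` has not yet been measured in this assay. It differs from compound 1 in one place: methyl in place of methoxy on an aromatic carbon. Among the compounds with values here, no measured pair shows what such a swap does, so the expectation rests on compound 1 alone. The step of no change at the digits printed from compound 1 to compound 4 (within the scatter) is expected to stay within the scatter, with no direction asserted. Compound 4 is therefore estimated at 25 mg/kg, within a range from 10 mg/kg to 60 mg/kg.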

Compound 4, minimum effective dose: > 50 mg/kg
Compound 4 was reported as a limit (the forecaster's own chance of this, stated with the estimate: 35%); middle value at least 2.0-fold (0.30 log units) away from the limit.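

Within the data shown here, this pair is the first measured case of methyl in place of methoxy on an aromatic carbon of this core, and it gives an at least 2.0-fold higher number from compound 1 to compound 4 (0.30 log units; that floor lies within the scatter). The value of compound 4 in this assay is a limit of the assay and not a number: the limit of > 50 mg/kg in this assay, at which 1 of the 4 values shown sits. The pair therefore supplies a floor for the step and no size, and since that floor lies within the scatter, it does not settle whether this swap moves the read-out beyond the scatter.

As far as these compounds go, how far the true number of compound 4 lies from that of compound 1 remains open. Also open, from the compounds shown here alone, is what a different group on the same carbon, such as an ethoxy, a chlorine or an amine, would do to the read-out on the core of compound 1.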